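The compounds below may be only part of what the source reports. "The series", "measured", "known", "first", "only" and "open" are said of these compounds alone.

Three close relatives of one shared core have been measured in an assay on CHO cells for displacement of a labelled ligand from adenosine receptor A3 (Homo sapiens), read by scintillation counting, with a stated time of 45 min, tested at 1 uM, in the presence of a further agent that is not named here; on this read-out higher numbers stand for more inhibition at the one concentration tested (going by the name of the read-out) and lower numbers for less inhibition. Compound 1 `CCCn1c(=O)[nH]c2nc(-c3ccc(S(=O)(=O)N4CCN(c5ccc(Cl)cc5F)CC4)cc3)[nH]c2c1=O` gives 14%. Compound 2 `CCCn1c(=O)[nH]c2nc(-c3ccc(S(=O)(=O)N4CCN(c5cccc(F)c5)CC4)cc3)[nH]c2c1=O`, which carries a 3-fluorophenyl on the amine nitrogen in a ring, gives 44%. Compound 3 `CCCn1c(=O)[nH]c2nc(-c3ccc(S(=O)(=O)N4CCN(C(C)c5ccccc5)CC4)cc3)[nH]c2c1=O`, with a 1-phenylethyl at that place, gives 0%. Compound 1 thus stands in the middle of the three: the change a number 30 percentage points higher from compound 1 to compound 2 (beyond the scatter), while the change a number 14 percentage points lower from compound 1 to compound 3 (beyond the scatter), and between the other two the change is a number 44 percentage points lower from compound 2 to compound 3 (beyond the scatter).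

Compound 4 `CCCn1c(=O)[nH]c2nc(-c3ccc(S(=O)(=O)N4CCN(c5ccccc5Cl)CC4)cc3)[nH]c2c1=O` differs from compound 1 only at the group on the amine nitrogen in a ring: 2-chlorophenyl in place of 4-chloro-2-fluorophenyl on an amine nitrogen in a ring. Going by the values given here, no measured pair shows exactly this swap. The nearest guide is the step from compound 1 to compound 2, where one substituted phenyl replaced another and the read-out rose modestly; the step to compound 3 shows that leaving the phenyl type altogether lowers it. Since compound 4 keeps a halogen-bearing phenyl, only a modest move is expected in this assay, most likely upward or none beyond the scatter. Compound 4 is therefore estimated at 22%, with a range from 5% to 45%. This estimate corresponds to an expected step of a number 8 percentage points higher from compound 1 to compound 4 (within the scatter).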

Compound 4, a percentage reported as inhibition, at one concentration (the size of the read-out at that concentration, not a potency): 32%
For compound 4 the middle estimate is 10 percentage points below the measured one; the measured number falls inside the stated range.
By their numbers in this assay, from the lowest: compound 3; then compound 1; then compound 4; then compound 2.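

In this assay, the step of a number 18 percentage points higher from compound 1 to compound 4 (beyond the scatter) shows that a phenyl with chlorine as its only halogen also reads higher than the 4-chloro-2-fluorophenyl, so compound 2 is no longer the only single-halogen phenyl to do so. The two single-halogen phenyls are not equivalent, as the step of a number 12 percentage points lower from compound 2 to compound 4 (beyond the scatter) shows, while the step of a number 32 percentage points higher from compound 3 to compound 4 (beyond the scatter) leaves the 1-phenylethyl of compound 3 lowest of the four. Nothing shown here explains these differences.

Because 2-chlorophenyl and 3-fluorophenyl differ in both the halogen and where it sits, the compounds leave open which of the two matters. An unsubstituted phenyl, a 2-fluorophenyl or a 3-chlorophenyl at this nitrogen would help separate them.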